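The compounds below may be only part of what the source reports. "The series", "measured", "known", "first", "only" and "open" are said of these compounds alone.

Measured in a functional assay on SW 1116 cells (Homo sapiens) for antiproliferative activity, read by MTT assay, with a stated time of 48 h; on this read-out higher numbers stand for weaker inhibition and lower numbers for stronger inhibition:
Compound 1 `S=c1oc(-c2ccc3c(c2)OCCO3)nn1CN1CCN(C(c2ccccc2)c2ccccc2)CC1`: 21600 nM
Compound 2 `S=c1oc(-c2ccc3c(c2)OCCO3)nn1CN1CCN(c2cccc(Cl)c2)CC1`: > 50000 nM

Of these two compounds, only compound 1 gives a true number, 21600 nM. Compound 2 gives only a limit of the assay, > 50000 nM, so its real position on the scale is not known. This is the situation summed up as the limit of > 50000 nM in this assay, at which 1 of the 2 values shown sits.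

Compound 3 `COc1ccc(N2CCN(Cn3nc(-c4ccc5c(c4)OCCO5)oc3=S)CC2)cc1` keeps the shared core of compound 2 and carries 4-methoxyphenyl in place of 3-chlorophenyl on an amine nitrogen in a ring. For the measured compounds named here, no step between measured compounds is available as a guide. A modest move toward stronger inhibition in this assay is expected, because compound 1 reads 21600 nM and shows that this family can give a number. The expected change is an at least 1.6-fold lower number from compound 2 to compound 3 (0.22 log units; that floor lies within the scatter). For compound 3 the estimated value is 30000 nM, with an expected range of 8000 nM to 80000 nM.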

Compound 3, half-maximal inhibitory concentration: 24200 nM
Estimate against measurement, compound 3: 1.2-fold (0.09 log units) above; the range from low to high includes it.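

In this assay, for the compounds shown here, the group on this ring nitrogen proves able to move the read-out: 4-methoxyphenyl in place of 3-chlorophenyl gives an at least 2.0-fold lower number from compound 2 to compound 3 (0.31 log units; beyond the scatter), the first step that can be read. Compound 3 thus shows that a single aromatic ring on this nitrogen can give a true number, which compound 2 did not show. On these data alone, that step is only a floor, and its full size is unknown: the limit of > 50000 nM in this assay, at which 1 of the 3 values shown sits.

The change alters both the kind of group on the phenyl ring and where it sits, so the compounds shown cannot tell these two apart. A 3-methoxyphenyl or 4-chlorophenyl group at the same nitrogen would separate them, and an unsubstituted phenyl would show what either group adds.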